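Compound 4: a urea in place of the hydroxyazetidine

The source may report more compounds than this note shows. Statements on the series, on what has been measured and on what is new or still open speak of the compounds shown alone.

Compound 1 `COc1cccc(S(=O)(=O)c2ccc3c(c2)CCC[C@H]3CN)c1`: 0.398 nM
Compound 2 `N#Cc1cccc(S(=O)(=O)c2ccc3c(c2)CCC[C@H]3C=N)c1`: 0.501 nM
Compound 3 `O=S(=O)(c1cccc(F)c1)c1ccc2c(c1)CCC[C@H]2CN1CC(O)C1`: 0.1 nM

Of the compounds shown here, three sharing one core have been measured in an assay on isolated protein for displacement of a labelled ligand from 5-hydroxytryptamine receptor 6 (Homo sapiens); a higher number here means a weaker inhibitor, a lower number a stronger inhibitor. Compound 1 gives 0.398 nM, compound 2 gives 0.501 nM, and compound 3 gives 0.1 nM. Compound 3 holds the lowest number of the three, its gap to compound 1 and to compound 2 lying beyond the scatter in each case, so it is the strongest inhibitor of the set.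

Compound 4 `CNC(=O)NC[C@@H]1CCCc2cc(S(=O)(=O)c3cccc(F)c3)ccc21` has not yet been measured in this assay. It differs from compound 3 in one place: (methylcarbamoyl)amino in place of 3-hydroxyazetidin-1-yl on a saturated chain carbon bound to a saturated ring carbon. Among the measured compounds shown here, no pair of measured compounds shows this kind of exchange, so the size of the step must be judged from the three values alone. The author expects compound 4 to come out weaker than compound 3, with the step of a 20-fold higher number from compound 3 to compound 4 (1.30 log units; beyond the scatter) reaching beyond the scatter. Accordingly compound 4 is estimated at 2 nM, within a range from 0.3 nM to 15 nM.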

Compound 4, inhibition constant: 0.398 nM
For compound 4 the middle estimate is 5.0-fold (0.70 log units) above the measured one; low and high end bracket the measured number.
By their numbers in this assay, from the lowest: compound 3; then compounds 1, 4 and 2 (each within the scatter of the next).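

In this assay, the exchange of 3-hydroxyazetidin-1-yl for (methylcarbamoyl)amino on a saturated chain carbon bound to a saturated ring carbon gives a 4.0-fold higher number from compound 3 to compound 4 (0.60 log units; beyond the scatter), a modest loss of binding that nevertheless lies beyond the scatter. The position therefore responds to the group placed there, yet it accepts a group with no ring, with a double bond outside aromatic rings and with 2 hydrogen-bond donors in place of 1, at only a modest cost. No measurement shown explains the size or direction of this step.

The compounds shown do not separate the contribution of the azetidine ring from that of its hydroxyl. Nor do they show whether an unsubstituted azetidin-1-yl, an acetamide or a carboxylic acid in this place would stand closer to compound 3 or to compound 4.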